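The source may report more compounds than this note shows. Statements on the series, on what has been measured and on what is new or still open speak of the compounds shown alone.

Of the compounds shown here, three have been tested so far in an assay on isolated protein with Bile acid receptor (Homo sapiens) as the target; on this read-out higher numbers stand for an effect only at larger amounts of compound and lower numbers for an effect already at smaller amounts. Compound 1 `COC(=O)/C=C/c1cccc(N(Cc2ccc(/C=C/C(=O)OC(C)(C)C)cc2OCc2ccccc2)C(=O)C2CCCCC2)c1` carries a benzyl group on the oxygen on the aromatic ring. In this assay compound 1 gives > 1000 nM, which is a limit of the assay rather than a number. Compound 2 `COC(=O)/C=C/c1cccc(N(Cc2ccc(/C=C/C(=O)OC(C)(C)C)cc2OC(=O)c2ccccc2)C(=O)C2CCCCC2)c1` carries a benzoyl group on that oxygen instead. In this assay compound 2 gives > 1000 nM, again a limit. Compound 3 `CCOC(=O)COc1cc(/C=C/C(=O)OC(C)(C)C)ccc1CN(C(=O)C1CCCCC1)c1cccc(/C=C/C(=O)OC)c1` carries an (ethoxycarbonyl)methyl group on that oxygen. In this assay compound 3 gives > 1000 nM, also a limit. Compound 3 therefore stands exactly where the other two stand, at the limit of > 1000 nM in this assay, at which 3 of the 3 values shown sit. The three steps between these compounds, a step that the two limits leave unreadable from compound 1 to compound 2, a step that the two limits leave unreadable from compound 1 to compound 3 and a step that the two limits leave unreadable from compound 2 to compound 3, cannot be given a size: both ends of each step sit at the same limit.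

Compound 4 `COC(=O)/C=C/c1cccc(N(Cc2ccc(/C=C/C(=O)OC(C)(C)C)cc2O)C(=O)C2CCCCC2)c1` differs from compound 3 by hydrogen in place of (ethoxycarbonyl)methyl on an oxygen on an aromatic ring. All three measured steps change the group on this same oxygen, yet none of them yields a readable size, so they give no direction for the present change. The step that the limit leaves unreadable from compound 3 to compound 4 is therefore expected to be small and of no certain direction. Compound 4 is expected to give 3000 nM, within a range from 500 nM to 20000 nM, with a good chance that the assay again reports only a limit.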

Compound 4, half-maximal effective concentration: > 1000 nM
Compound 4 ended at the assay's limit (the forecaster's own chance of this, stated with the estimate: 75%); the middle value does not contradict the limit.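

No step from compound 1, compound 2 or compound 3 to compound 4 can be read, as both ends of each step sit at one limit: the limit of > 1000 nM in this assay, at which 4 of the 4 values shown sit.

The compounds shown leave open what true value lies behind each limit, and whether the group on the oxygen on the aromatic ring matters at all.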